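Lengthening the Side Chain of Compound 1

The source may hold more compounds than are shown below. What is called first, only, known or untested is meant among the compounds shown, and "the series" means these compounds.

Within the data shown here, in an ADME assay on S9 fraction from liver (Rattus norvegicus, strain Sprague-Dawley) for metabolic stability, read by LC-MS, using NADPH, with stated times of 5 min and 60 min, tested at 5 uM (on this read-out higher numbers stand for a more stable compound and lower numbers for a less stable compound), compound 1 `COc1cc(C2CN(C(=O)c3cc(OC[C@@H](O)CO)ccn3)C2)ccc1OCc1ccc(C2CC2)cc1` gives 61%, the higher of the two numbers available so far, while compound 2 `CCc1ccc(COc2ccc(C3CN(C(=O)c4cc(COC[C@@H](O)CO)ccn4)C3)cc2OC)cc1` gives 13%, a gap beyond the scatter. Compound 3 `COc1cc(C2CN(C(=O)c3cc(COC[C@H](O)CO)ccn3)C2)ccc1OCc1ccc(C2CC2)cc1` keeps the core of compound 1 but has (2,3-dihydroxypropoxy)methyl in place of 2,3-dihydroxypropoxy on an aromatic carbon, opposite the ring nitrogen ((2,3-dihydroxypropoxy)methyl in place of 2,3-dihydroxypropoxy on an aromatic carbon). Among the measured compounds shown here, no measured pair shows this change on its own. For the measured compounds named here, the only guide is compound 2, which also carries (2,3-dihydroxypropoxy)methyl and stands at 13%, although it is not otherwise identical to compound 3. A fall is therefore expected, but a less severe one, and the estimated step in this assay is a number 25 percentage points lower from compound 1 to compound 3 (beyond the scatter). For compound 3 the expected value is 36%, with an estimated range from 14% to 60%.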

Compound 3, percent of the compound remaining: 52%
Compound 3: middle estimate off by 16 percentage points, on the low side; the measured number falls inside the stated range.
By their numbers in this assay, from the lowest: compound 2; then compounds 3 and 1 (each within the scatter of the next).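

Among these compounds, this pair gives the first reading of the change on its own. In this assay the swap of 2,3-dihydroxypropoxy for (2,3-dihydroxypropoxy)methyl on the aromatic carbon opposite the ring nitrogen gives a number 9 percentage points lower from compound 1 to compound 3 (within the scatter) and that step lies within the scatter, so on the core of compound 1 this read-out shows no clear cost for the longer side chain. No measurement here explains why the change has so little effect.

Still open, on these data alone, is what an amine, a carboxylic acid or a still longer chain would do on this same aromatic carbon. Among the compounds shown here, also open is whether the step stays this small on any other core, as this single pair is the only one that shows the change alone.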